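Benzyloxy to 3-((tert-butoxycarbonyl)amino)propoxy: solubility outlook

A few compounds are considered here, and "the series" means these few. Any claim that something is new, unique, unknown or untested is made for them only; others in the source may bear on it.

Within the data shown here, compound 2 `COc1cc2ncnc(-n3nc(-c4ccccn4)nc3N)c2cc1OCc1ccccc1` holds the lower of the two numbers measured so far in a physicochemical assay for solubility, in phosphate buffer, with a stated time of 18 h, at pH 7.4 (on this read-out higher numbers stand for higher solubility and lower numbers for lower solubility), where compound 2 gives 58000 nM; compound 1 `COc1cc2ncnc(-n3nc(N)nc3N)c2cc1OC` gives 83000 nM, a gap that lies within the usual scatter. Compound 3 `COc1cc2ncnc(-n3nc(-c4ccccn4)nc3N)c2cc1OCCCNC(=O)OC(C)(C)C` differs from compound 2 by 2-((tert-butoxycarbonyl)amino)ethyl in place of phenyl on a saturated chain carbon bound to an oxygen on an aromatic ring. Among the measured compounds shown here, no step between measured compounds is available to calibrate a change of this kind. The move from phenyl to a chain carrying one hydrogen-bond donor and two hydrogen-bond acceptors is expected to shift this assay little, perhaps slightly upward, so the step of a 1.4-fold higher number from compound 2 to compound 3 (0.14 log units; within the scatter) is estimated as small. Compound 3 is expected to give 80000 nM, within 30000 nM to 200000 nM.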

Compound 3, solubility: 2000 nM
Estimate against measurement, compound 3: 40-fold (1.60 log units) above, and the stated range ends above it.
By their numbers in this assay, from the lowest: compound 3; then compounds 2 and 1 (each within the scatter of the next).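

In this assay this place, a saturated chain carbon bound to an oxygen on an aromatic ring, responds strongly: 2-((tert-butoxycarbonyl)amino)ethyl in place of phenyl gives a 29-fold lower number from compound 2 to compound 3 (1.46 log units; beyond the scatter) on the shared core. Compound 1 and compound 2 differ in more than one place, so they gave no reading of this position. No measurement at hand bears on the reason for the step.

Open, on these data alone, is whether the step belongs to the carbamate end or to the chain itself. The free primary amine on the same chain, or a longer chain ending in a carboxylic acid, would separate these.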